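This account rests on a few compounds, and the source may have more. Where it says the series, first, only, none or still open, it means among the compounds named here.

Compound 1 `NS(=O)(=O)c1cccc(/N=C2\NC(=O)/C(=C3/C(=O)Nc4ccccc43)S2)c1` was tested in a functional assay on MCF7 cells (Homo sapiens) for antiproliferative activity, read by MTT assay; on this read-out lower numbers stand for stronger inhibition and higher numbers for weaker inhibition. Compound 1 gives only a limit there, > 200000 nM, so its result is not a number but a boundary of what the measurement can report. Compound 2 `COc1ccc2c(c1)/C(=C1/S/C(=N/c3ccc(S(N)(=O)=O)cc3)NC1=O)C(=O)N2` shares the same core and differs from compound 1 in more than one place; in this assay compound 2 gives 125000 nM. Taken together, the two values show that both compounds slow cell growth only at very high concentrations, and the ceiling of the measurement is marked by the limit of > 200000 nM in this assay, at which 1 of the 2 values shown sits. Compound 3 `COc1ccc2c(c1)/C(=C1/S/C(=N/c3cccc(S(N)(=O)=O)c3)NC1=O)C(=O)N2` is the next compound to be measured. It differs from compound 1 by methoxy in place of hydrogen on an aromatic carbon. Going by the values given here, no measured step of this single change exists among the compounds at hand, so the expectation rests on the weak values of compound 1 and compound 2 alone. The step of an at least 1.1-fold lower number from compound 1 to compound 3 (0.04 log units; that floor lies within the scatter) is expected to stay within the scatter, or at most to move slightly toward stronger inhibition. Compound 3 is therefore estimated at 180000 nM, in a range from 60000 nM to 500000 nM, with a real chance that this assay again reports only a limit.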

Compound 3, half-maximal inhibitory concentration: > 200000 nM
Compound 3 ended at the assay's limit (the forecaster's own chance of this, stated with the estimate: 55%); middle value at least 1.1-fold (0.04 log units) away from the limit.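

Compound 1 and compound 3 both end at a limit in this assay, not at a number, so no step can be read between them: the limit of > 200000 nM in this assay, at which 2 of the 3 values shown sit.

The compounds shown leave open whether methoxy in place of hydrogen on an aromatic carbon changes growth inhibition at all, in either direction.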